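Cytotoxicity limits in a four-compound series

This account rests on a few compounds, and the source may have more. Where it says the series, first, only, none or still open, it means among the compounds named here.

Compound 1 `CN(C)c1ccc(/C=C2\CCC/C(=C\c3ccccc3[N+](=O)[O-])C2=O)cc1` was run in an ADME assay on HPC cells (Homo sapiens) for cytotoxicity, with a stated time of 24 h; on this read-out lower numbers stand for higher toxicity in this test and higher numbers for lower toxicity in this test. In this test compound 1 gives > 400000 nM, a limit of the assay rather than a number. Compound 2 `Cc1ccc(/C=C2\CCC/C(=C\c3ccccc3[N+](=O)[O-])C2=O)cc1` gives the limit > 400000 nM in this assay. Compound 3 `CN(C)c1ccc(/C=C2\CCC/C(=C\c3cccc([N+](=O)[O-])c3)C2=O)cc1` gives the limit > 400000 nM in this assay. The step that the two limits leave unreadable from compound 1 to compound 2 corresponds to the change (methyl in place of dimethylamino on an aromatic carbon). The two cores differ as described by 3-nitrophenyl in place of 2-nitrophenyl on a double-bonded chain carbon bound to a double-bonded ring carbon, and the step that the two limits leave unreadable from compound 1 to compound 3 stays unreadable. Compound 4 `Cc1ccc(/C=C2\CCC/C(=C\c3cccc([N+](=O)[O-])c3)C2=O)cc1` is not yet measured; it differs from compound 3 by methyl in place of dimethylamino on an aromatic carbon, the same change as from compound 1 to compound 2, at a place worded identically. A step of a number no higher from compound 3 to compound 4 (the limit leaves the size open) is expected, resting on the observation that (the limit of > 400000 nM in this assay, at which 3 of the 3 values shown sit). Compound 4 is therefore estimated at 400000 nM, between 200000 nM and 800000 nM, most probably reported again as a limit.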

Compound 4, half-maximal cytotoxic concentration: 192000 nM
Beside the measured number, compound 4's estimate is 2.1-fold (0.32 log units) above it; measured number below the stated range.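

In this assay, changing 4-(dimethylamino)phenyl to 4-methylphenyl on the core of compound 3 gives an at least 2.0-fold lower number from compound 3 to compound 4 (0.31 log units; beyond the scatter). On the core of compound 1 the same change ends in compound 2, which gives > 400000 nM, a limit of the assay and not a number. The steps between limits cannot be read, so a lower number is shown for the core of compound 3 only, while neither the full size of that step nor its transfer to the core of compound 1 is shown: the limit of > 400000 nM in this assay, at which 3 of the 4 values shown sit.

Going by these compounds, whether a carboxylic acid or a longer alkyl chain in place of the methyl of compound 4 would shift the number in this assay remains open. On these data alone, an amine such as piperidine in place of dimethylamino is equally open.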